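From an Alkylamine to a Urea on the Shared Core

The source may hold more compounds than are shown below. What is called first, only, known or untested is meant among the compounds shown, and "the series" means these compounds.

Compound 1 `CCCNc1nc2ccc(-c3cnc(Cl)c(NS(=O)(=O)c4ccc(F)cc4)c3)cc2s1` carries a propylamino group on the shared core. In a functional assay on HCT-116 cells (Homo sapiens) for antiproliferative activity, read by MTT assay, with a stated time of 72 h (a higher number here means a weaker inhibitor, a lower number a stronger inhibitor), compound 1 gives only a limit, > 20000 nM. It stands at the limit of > 20000 nM in this assay, at which 2 of the 3 values shown sit, so no number is known for it. Compound 2 `COc1ncc(-c2ccc3nc(NC(=O)NCCN(C)C)sc3c2)cc1NS(=O)(=O)c1ccc(F)cc1` carries a urea in that position, and in this assay compound 2 gives 240 nM. Compound 3 `CCOC(=O)CNc1nc2ccc(-c3cnc(OC)c(NS(=O)(=O)c4ccc(F)cc4)c3)cc2s1` has a plain amine there; in this assay compound 3 gives only a limit, > 20000 nM. The step of an at least 83-fold higher number from compound 2 to compound 3 (1.92 log units; beyond the scatter) shows that swapping the urea for an alkylamine costs heavily. Compound 4 `O=C(Nc1nc2ccc(-c3cnc(Cl)c(NS(=O)(=O)c4ccc(F)cc4)c3)cc2s1)NC1CC1` differs from compound 1 by cyclopropylcarbamoyl in place of propyl on a nitrogen on an aromatic ring, which runs the other way, from propylamino to (cyclopropylcarbamoyl)amino. A step of an at least 33-fold lower number from compound 1 to compound 4 (1.52 log units; beyond the scatter) is therefore expected. Compound 4 is estimated at 600 nM, within 100 nM to 5000 nM.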

Compound 4, half-maximal inhibitory concentration: 1750 nM
Beside the measured number, compound 4's estimate is 2.9-fold (0.46 log units) below it; low and high end bracket the measured number.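

The earlier step showed a urea on this nitrogen being lost, with a large penalty; this one shows a urea entering on a different compound, and the effect runs the other way. The value of compound 1 remains a limit, not a number, in this assay: the limit of > 20000 nM in this assay, at which 2 of the 4 values shown sit. Even so, the gain is large: an at least 11-fold lower number from compound 1 to compound 4 (1.05 log units; beyond the scatter).

As far as these compounds go, what remains open is how much of this gain needs the full urea. A simple acetyl amide on this nitrogen, or a cyclopropylamino group, would separate the carbonyl from the urea's second nitrogen.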